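This account rests on a few compounds, and the source may have more. Where it says the series, first, only, none or still open, it means among the compounds named here.

Compound 1 `O=[N+]([O-])c1ccc2[nH]cc(C(c3ccccc3)c3cc4ccccc4o3)c2c1` is measured in a functional assay on SiHa cells (Homo sapiens) for cytotoxicity (a lower number here means a stronger inhibitor, a higher number a weaker inhibitor), where compound 1 gives 40400 nM. Compound 2 `O=[N+]([O-])c1ccc2[nH]cc(C(c3ccccc3)c3cc4cc(Cl)ccc4o3)c2c1` reaches only a limit of the assay, giving > 100000 nM. The change between them is chloro in place of hydrogen on an aromatic carbon, and it produced an at least 2.4-fold higher number from compound 1 to compound 2 (0.39 log units; beyond the scatter), a step whose size is bounded by the limit of > 100000 nM in this assay, at which 1 of the 3 values shown sits.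

Compound 3 `CC(C)(C)c1cc(C(C)(C)C)c2oc(C(c3ccccc3)c3c[nH]c4ccccc34)cc2c1` has a different core; how its core differs from that of compound 1 is not broken down here. In this assay compound 3 gives 61600 nM.

Compound 4 `CC(C)(C)c1cc(C(C)(C)C)c2oc(C(c3ccc(Cl)cc3)c3c[nH]c4ccccc34)cc2c1` is not yet measured. It differs from compound 3 by chloro in place of hydrogen on an aromatic carbon. This is the same kind of change as that from compound 1 to compound 2, but not the same: there the chloro entered on a ring that is part of a fused or bridged system of two rings, meta to a fused ring and para to a fused ring, whereas here it enters para to a large group. Because of an at least 2.4-fold higher number from compound 1 to compound 2 (0.39 log units; beyond the scatter), the expected step is a 1.9-fold higher number from compound 3 to compound 4 (0.29 log units; within the scatter). Compound 4 is therefore estimated at 120000 nM, with a fair chance that only a limit is reported.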

Compound 4, half-maximal inhibitory concentration: 49800 nM
Estimate against measurement, compound 4: 2.4-fold (0.38 log units) above; measured number below the stated range.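

Chloro in place of hydrogen on the phenyl ring gives a 1.2-fold lower number from compound 3 to compound 4 (0.09 log units; within the scatter) in this assay, so on this core the change leaves no readable effect. The step therefore did not carry over in size from the earlier core: the same change on two cores in this assay, an at least 2.4-fold higher number (0.39 log units; beyond the scatter) from compound 1 to compound 2 and a 1.2-fold lower number (0.09 log units; within the scatter) from compound 3 to compound 4, at least 3.0-fold (0.48 log units) apart, beyond the scatter of two such steps. This shows that the earlier step cannot simply be transferred, but it does not show what causes the gap, since the chloro sits in a different place on each core and the earlier step is bounded by a limit: the limit of > 100000 nM in this assay, at which 1 of the 4 values shown sits.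

As far as these compounds go, it remains open whether a chloro on the phenyl ring of compound 1 would match the step seen here. From the compounds shown here alone, it also remains open whether a methoxy or an amine at that place would behave like chloro.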